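A few compounds are considered here, and "the series" means these few. Any claim that something is new, unique, unknown or untested is made for them only; others in the source may bear on it.

Measured compounds in the series:
- Compound 1 `CC(C)(C)n1ncc(OCc2nnc(-c3ccc(Cl)cc3)s2)c(Cl)c1=O`: in a functional assay on the whole organism for inhibition, with Mythimna separata as the target, with a stated time of 5 days (a lower number here means that less compound is needed, a higher number that more compound is needed for the effect), compound 1 gives 106 ug/mL.
- Compound 2 `CCCCn1ncc(OCc2nnc(-c3ccccc3)o2)c(Cl)c1=O`: compound 2 reaches only the assay limit, > 300 ug/mL.
- Compound 3 `CC(C)(C)n1ncc(OCc2nnc(-c3cccc(F)c3)o2)c(Cl)c1=O`: compound 3 gives 7.1 ug/mL.

Compound 1 holds the highest of the two numbers given; compound 3 lies well beyond the scatter below it. The value of compound 2 is a limit (the limit of > 300 ug/mL in this assay, at which 1 of the 3 values shown sits), not a number.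

Compound 4 `CC(C)(C)n1ncc(OCc2nnc(-c3ccccc3)s2)c(Cl)c1=O` is not yet measured. It differs from compound 1 by hydrogen in place of chloro on an aromatic carbon. Going by the values given here, no measured pair carries this same change, so the size of the step is uncertain. In this assay compound 4 is expected to sit near compound 1, with at most a modest rise, an estimated step of a 1.4-fold higher number from compound 1 to compound 4 (0.15 log units; within the scatter). The estimate for compound 4 is 150 ug/mL, with a range from 40 ug/mL to 450 ug/mL.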

Compound 4, half-maximal effective concentration: 200 ug/mL
Beside the measured number, compound 4's estimate is 1.3-fold (0.12 log units) below it; low and high end bracket the measured number.
By their numbers in this assay, from the lowest: compound 3; then compounds 1 and 4 (each within the scatter of the next). At a limit, above all of these: compound 2.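

In this assay, going by these compounds alone, going from 4-chlorophenyl to phenyl gives a 1.9-fold higher number from compound 1 to compound 4 (0.28 log units; within the scatter), the first reading of a change at this place. On this shared core, the numbers do not separate chloro from hydrogen on the aromatic carbon para to a large group. Nothing at hand bears on why this step is so small.

Still open, on these data alone, is whether a methoxy group, a trifluoromethyl group or an amine at this place would move the number beyond the scatter. Whether chloro and hydrogen also stay this close on the cores of compound 2 and compound 3 is open too.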